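Capping the free hydroxy of compound 1 with methyl

The source may hold more compounds than are shown below. What is called first, only, known or untested is meant among the compounds shown, and "the series" means these compounds.

Compound 1 `COc1ccc(-c2cn(-c3ccc(OC(F)(F)F)cc3)nn2)cc1O` carries a trifluoromethyl on an oxygen on one aromatic ring and a free hydroxy on the other. In a functional assay on MDA-MB-231 cells (Homo sapiens) for cytotoxicity, read by MTT assay (on this read-out higher numbers stand for weaker inhibition and lower numbers for stronger inhibition), compound 1 gives > 10000 nM, which is a limit of the assay rather than a number. Compound 2 `COc1ccc(-n2cc(-c3ccc(OC)c(O)c3)nn2)cc1` has methyl in place of trifluoromethyl on that oxygen, and in this assay compound 2 gives > 10000 nM, again a limit. Compound 3 `COc1ccc(-c2cn(-c3ccc(Oc4ccccc4)cc3)nn2)cc1O` has phenyl in place of trifluoromethyl on the same oxygen, and in this assay compound 3 gives > 10000 nM, also a limit. Hence the steps a step that the two limits leave unreadable from compound 1 to compound 2, a step that the two limits leave unreadable from compound 1 to compound 3 and a step that the two limits leave unreadable from compound 2 to compound 3 cannot be read, as the limit of > 10000 nM in this assay, at which 3 of the 3 values shown sit, shows.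

Compound 4 `COc1ccc(-c2cn(-c3ccc(OC(F)(F)F)cc3)nn2)cc1OC` differs from compound 1 by methyl in place of hydrogen on an oxygen on an aromatic ring. For the measured compounds named here, none of the measured steps touches this oxygen; all of them vary the group on the other oxygen. Going by the values given here, no measured step bears on the change, and the three limits only say where the whole set sits. Compound 4 is expected to remain at the limit in this assay, so the estimated step that the limit leaves unreadable from compound 1 to compound 4 amounts to an expectation of no readable change. For compound 4 the estimate in this assay is 15000 nM, between 4000 nM and 60000 nM.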

Compound 4, half-maximal inhibitory concentration: > 1000 nM
Compound 4 ended at the assay's limit; the forecaster's own chance of this, stated with the estimate: 85%; the middle value is on the limit's open side.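

In this assay compound 4 gives > 1000 nM, a limit of the assay and not a number. Compound 1 also sits at a limit, so the step from compound 1 to compound 4 cannot be read. The compounds shown leave open whether methyl on that free hydroxy changes anything, and how strong any of the four compounds is in this assay.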